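The compounds below may be only part of what the source reports. "The series", "measured", "known", "first", "only" and "open" are said of these compounds alone.

Of the compounds shown here, three built on a shared core have been tested in a functional assay on BXPC-3 cells (Homo sapiens) for antiproliferative activity, read by MTT assay, with a stated time of 24 h (a lower number here means a stronger inhibitor, a higher number a weaker inhibitor), and they differ only in the group on an amide-type nitrogen. Compound 1 (`CCn1c(C(=O)N[C@@H](CC(=O)OC)C(=O)OC)ccc1C(CC)(CC)c1ccc(OCS(=O)(=O)c2ccccc2)c(C)c1`) gives > 50000 nM as a limit of the assay and not as a number. Compound 2 (`CCn1c(C(=O)N[C@@H](C)CO)ccc1C(CC)(CC)c1ccc(OCS(=O)(=O)c2ccccc2)c(C)c1`) gives 15300 nM as a measured number. Compound 3 (`CCn1c(C(=O)NC2(CO)CC2)ccc1C(CC)(CC)c1ccc(OCS(=O)(=O)c2ccccc2)c(C)c1`) gives 45400 nM and so holds the higher of the two measured numbers. Compound 4 (`CCn1c(C(=O)N[C@@H](CO)C(C)C)ccc1C(CC)(CC)c1ccc(OCS(=O)(=O)c2ccccc2)c(C)c1`) has not yet been measured. It carries 1-(hydroxymethyl)-2-methylpropyl in place of 1-(hydroxymethyl)cyclopropyl on that nitrogen (1-(hydroxymethyl)-2-methylpropyl in place of 1-(hydroxymethyl)cyclopropyl on an amide-type nitrogen), so it has no ring in this group. The steps of an at least 3.2-fold lower number from compound 1 to compound 2 (0.51 log units; beyond the scatter) and an at least 1.1-fold lower number from compound 1 to compound 3 (0.04 log units; that floor lies within the scatter) rest on a limit and say little here. The closest guide is a 3.0-fold higher number from compound 2 to compound 3 (0.47 log units; beyond the scatter) and it runs from an open chain to the cyclopropyl ring. Read in reverse, that step suggests a modest fall in the number on opening the ring, although the larger chain of compound 4 remains untested. The expected change is a 2.1-fold lower number from compound 3 to compound 4 (0.31 log units; beyond the scatter) in this assay by this estimate. For compound 4 the estimated value is 22000 nM within an expected range of 9000 nM to 50000 nM in this assay before any measurement.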

Compound 4, half-maximal inhibitory concentration: 13200 nM
Beside the measured number, compound 4's estimate is 1.7-fold (0.22 log units) above it; the range from low to high includes it.
By their numbers in this assay, from the lowest: compounds 4 and 2 (each within the scatter of the next); then compound 3. At a limit, above all of these: compound 1.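

In this assay, the ring matters more clearly than before: with an open chain in place of the cyclopropyl ring, the result is a 3.4-fold lower number from compound 3 to compound 4 (0.54 log units; beyond the scatter), whereas the larger open chain gives a 1.2-fold lower number from compound 2 to compound 4 (0.06 log units; within the scatter), so enlarging 1-(hydroxymethyl)ethyl to 1-(hydroxymethyl)-2-methylpropyl brings no readable change. Compounds 2 and 4 thus form an open-chain pair that cannot be told apart in this assay, and compound 3, with its ring, is the one that stands apart from them. The comparison with the diester group reads as an at least 3.7-fold lower number from compound 1 to compound 4 (0.57 log units; beyond the scatter), which is only a floor. Compound 1 gives a limit of the assay and not a number: the limit of > 50000 nM in this assay, at which 1 of the 4 values shown sits.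

Going by these compounds, compounds 2, 3 and 4 all carry a hydroxymethyl group, so it remains open what an amine or a carboxylic acid in its place would do, or what a longer chain such as 1-(hydroxymethyl)pentyl would do. Also open, on these data alone, is how the mirror-image form of compound 4, with its one defined stereocentre inverted, would compare.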